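The source may report more compounds than this note shows. Statements on the series, on what has been measured and on what is new or still open speak of the compounds shown alone.

Measured in a functional assay for inhibition, with Rattus norvegicus as the target; on this read-out higher numbers stand for weaker inhibition and lower numbers for stronger inhibition:
- compound 1 `COc1c(C)c(C)c2c(c1C)CCC(C)(/C=[N+](\[O-])C(C)(C)C)O2` gives 3700000 nM
- compound 2 `Cc1c(C)c2c(c(C)c1O)CCC(C)(/C=[N+](\[O-])C1CC1)O2` gives 1100000 nM
- compound 3 `COc1c(C)c(C)c2c(c1C)CCC(C)(/C=[N+](\[O-])C1CC1)O2` gives 1200000 nM

Compound 3 stands level with compound 2, the two lying within the scatter of each other. Compound 1 has the clearly higher number, and a 3.1-fold lower number from compound 1 to compound 3 (0.49 log units; beyond the scatter) is a modest step beyond the scatter.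

Compound 4 `CC(=O)Oc1c(C)c(C)c2c(c1C)CCC(C)(/C=[N+](\[O-])C1CC1)O2` keeps the rest of compound 3 and alters one group, with acetyl in place of methyl on an oxygen on an aromatic ring. Of the two measured steps, the change of tert-butyl to cyclopropyl on a double-bonded nitrogen lies elsewhere in the structure and offers little guidance here. The step that bears on this change is methyl in place of hydrogen on that same oxygen, a 1.1-fold higher number from compound 2 to compound 3 (0.04 log units; within the scatter), and it stays within the scatter. For the measured compounds named here, no compound with acetyl on that oxygen has been measured, so the expectation rests on this single step. No step beyond the scatter, in either direction, is therefore expected in this assay for this change. The expected step is a 1.1-fold lower number from compound 3 to compound 4 (0.04 log units; within the scatter) in the estimate given here. For compound 4 the estimated value is 1100000 nM, with an expected range from 500000 nM to 2500000 nM as its limits.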

Compound 4, half-maximal inhibitory concentration: 590000 nM
Compound 4: the middle estimate sits 1.9-fold (0.27 log units) above what was measured; measured number inside the range.
By their numbers in this assay, from the lowest: compounds 4, 2 and 3 (each within the scatter of the next, the first and the last beyond it); then compound 1.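

In this assay, the oxygen on the aromatic ring had seemed indifferent to its substituent, since hydrogen and methyl there gave values within the scatter of each other. Acetyl is the first group at this place to give a step beyond the scatter, though only a modest one, with a 2.0-fold lower number from compound 3 to compound 4 (0.31 log units; beyond the scatter), while the comparison with the free hydroxyl, a 1.9-fold lower number from compound 2 to compound 4 (0.27 log units; within the scatter), stays within the scatter. The acetoxy compound is thus separated from the methoxy compound but not from the hydroxyl compound, so these three compounds form a chain of close values rather than a clear order, and no measured explanation is available for the gap between methoxy and acetoxy at this place.

The compounds shown leave open whether a longer acyl chain such as butyryl, or a carbamate on the same oxygen, would extend this small step or leave the value where it is. They also leave open whether acetyl on this oxygen would give a similar step with tert-butyl rather than cyclopropyl on the double-bonded nitrogen.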